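This account rests on a few compounds, and the source may have more. Where it says the series, first, only, none or still open, it means among the compounds named here.

Measured compounds:

compound 1: `Oc1ccccc1/C=C/c1ccccc1O`, 24.3 ug/mL
compound 2: `Oc1cccc(/C=C/c2ccccc2O)c1`, 18 ug/mL
compound 3: `Nc1ccccc1/C=C/c1ccccc1O`, 27 ug/mL

All three were tested in an ADME assay on HEK293 cells (Homo sapiens) for inhibition, read by MTT assay, with a stated time of 2 days; on this read-out higher numbers stand for weaker inhibition and lower numbers for stronger inhibition. Compound 2 has the same atoms as compound 1, joined differently; the difference between the two cores is not broken down here. The number for compound 2 lies within the usual scatter of both compound 1 and compound 3, so the three numbers are not told apart by this assay.

Compound 3 differs from compound 1 by amino in place of hydroxy on an aromatic carbon. The step it made is a 1.1-fold higher number from compound 1 to compound 3 (0.05 log units; within the scatter), so this change left the number where it was as far as the assay can tell.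

The unmeasured compound 4, `Nc1ccccc1/C=C/c1cccc(O)c1`, differs from compound 2 by amino in place of hydroxy on an aromatic carbon. For the measured compounds named here, this is the same change as the one from compound 1 to compound 3, made on the core of compound 2 instead.

For compound 4 the expected step is a 1.1-fold higher number from compound 2 to compound 4 (0.05 log units; within the scatter), an expectation that rests on compound 1 and compound 3, where the same change gave a 1.1-fold higher number from compound 1 to compound 3 (0.05 log units; within the scatter). On that basis compound 4 is estimated at 20 ug/mL in this assay. Going by the values given here, the estimate for compound 4 is expected to fall between 10 ug/mL and 40 ug/mL, since only one earlier step supports it and the core change from compound 1 to compound 2 is not broken down.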

Compound 4, half-maximal inhibitory concentration: 20 ug/mL
The estimate for compound 4 equals the measured number at the digits printed; low and high end bracket the measured number.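

In this assay, amino in place of hydroxy on an aromatic carbon gave a 1.1-fold higher number from compound 2 to compound 4 (0.05 log units; within the scatter), so this change again left the number where it was as far as the assay can tell. Set beside the earlier step, the change carried from one core to the other with no difference that the assay can detect: the same change on two cores in this assay, a 1.1-fold higher number (0.05 log units; within the scatter) from compound 1 to compound 3 and a 1.1-fold higher number (0.05 log units; within the scatter) from compound 2 to compound 4, 1.0-fold (0.00 log units) apart, within the scatter of two such steps. For the compounds shown here, this shows that the swap is silent on both of these cores, but neither step stands beyond the scatter, so the agreement is between two steps that cannot be told from no step at all, and it does not show that a change with a real effect on the number would carry across these cores in the same way, or that this one would hold on any further core.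

The compounds shown leave open whether any group at this place can move the number in this assay, since only hydroxy and amino appear there, and a methoxy group, a carboxylic acid or an amide could behave differently. They also leave open what happens when the hydroxy on the other ring is replaced or removed, as every compound shown keeps it.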